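The source may hold more compounds than are shown below. What is called first, only, known or untested is meant among the compounds shown, and "the series" means these compounds.

Compound 1 `CCCCCCCc1cn(C(c2ccccc2)c2ccccc2)nn1` and compound 2 `CCCCCCCCCCc1cn(C(c2ccccc2)c2ccccc2)nn1` share one core, and compound 3 `CCCc1cn(Cc2ccccc2)nn1` is built on a different one; the difference between the two cores is not broken down here. In an assay on isolated protein for inhibition of Aromatase (Homo sapiens), read by fluorescence and colorimetric assay, with a stated time of 30 min (a higher number here means a weaker inhibitor, a lower number a stronger inhibitor), compound 1 gives 19400 nM. Compound 2 carries propyl in place of hydrogen on a saturated chain carbon, seven bonds along the chain from an aromatic carbon and in this assay gives 13500 nM, so that the step of a 1.4-fold lower number from compound 1 to compound 2 (0.16 log units; within the scatter) stays inside the usual scatter of the measurement. Compound 3, on its own core, gives 12600 nM in this assay, a number that sits within the scatter of both compound 1 and compound 2, so no order among the three can be read from these figures.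

Compound 4 `CCCCCCc1cn(Cc2ccccc2)nn1` is not yet measured. It differs from compound 3 by propyl in place of hydrogen on a saturated chain carbon, three bonds along the chain from an aromatic carbon. Within the data shown here, this is the same kind of change as the one from compound 1 to compound 2, but not the same: there the added propyl sits on a saturated chain carbon seven bonds along the chain from an aromatic carbon, whereas here it sits three bonds along the chain from an aromatic carbon.

Among the measured compounds shown here, because the one measured example of this kind of change, a 1.4-fold lower number from compound 1 to compound 2 (0.16 log units; within the scatter), stayed within the scatter, compound 4 is expected to sit close to compound 3, with a step of about a 1.3-fold lower number from compound 3 to compound 4 (0.10 log units; within the scatter). On that basis the estimate for compound 4 in this assay is 10000 nM, with a plausible range from 4000 nM to 25000 nM.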

Compound 4, half-maximal inhibitory concentration: 7470 nM
Compound 4: middle estimate off by 1.3-fold (0.13 log units), on the high side; the measured number falls inside the stated range.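

In this assay the new step, a 1.7-fold lower number from compound 3 to compound 4 (0.23 log units; within the scatter), stays inside the usual scatter, and set beside the earlier step it cannot be told apart from it: the same change on two cores in this assay, a 1.4-fold lower number (0.16 log units; within the scatter) from compound 1 to compound 2 and a 1.7-fold lower number (0.23 log units; within the scatter) from compound 3 to compound 4, 1.2-fold (0.07 log units) apart, within the scatter of two such steps. Read plainly, propyl in place of hydrogen on a saturated chain carbon gave no step beyond the scatter on either core, so in this small set the change carries from one core to the other in that limited sense, with the two steps in agreement. This does not show that the change has a real effect of its own on either core, and it does not show a shared trend: both steps are small, there are only two of them, and the place differs, seven bonds along the chain from an aromatic carbon in one case and three bonds in the other.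

The compounds shown leave open whether a longer chain on the core of compound 3 would give a step beyond the scatter. They also leave open how a chain carrying an amine or a carboxylic acid would read in this assay, as every substituent at this place here is a plain saturated chain.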